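Lengthening the hydroxy chain on a shared core

This account rests on a few compounds, and the source may have more. Where it says the series, first, only, none or still open, it means among the compounds named here.

- compound 1 `CC[C@@H]1O[C@H](COCc2ccccc2)[C@@H](OCc2ccccc2)[C@H](OCc2ccccc2)[C@H]1O` gives 34200 nM
- compound 2 `OCC[C@@H]1O[C@H](COCc2ccccc2)[C@@H](OCc2ccccc2)[C@H](OCc2ccccc2)[C@H]1O` gives 39700 nM

In a functional assay on HOS cells (Homo sapiens) for antiproliferative activity, read by sulforhodamine B assay (a lower number here means a stronger inhibitor of growth, a higher number a weaker inhibitor of growth), the values of compound 1 and compound 2 lie within the scatter of each other, so neither can be ranked above the other. Within the data shown here, the single measured step between them (a 1.2-fold higher number from compound 1 to compound 2 (0.06 log units; within the scatter)) puts hydroxy in place of hydrogen.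

The next compound is compound 3 (`OCCC[C@@H]1O[C@H](COCc2ccccc2)[C@@H](OCc2ccccc2)[C@H](OCc2ccccc2)[C@H]1O`). It differs from compound 2 (hydroxymethyl in place of hydroxy on a saturated chain carbon, two bonds along the chain from a saturated ring carbon) by hydroxymethyl in place of hydroxy on a saturated chain carbon, two bonds along the chain from a saturated ring carbon, which turns 2-hydroxyethyl into 3-hydroxypropyl.

The earlier step is a different change, so it is only a loose guide, and two compounds show no trend. Among the measured compounds shown here, still, it is the only step that bears on this one. Since that step (a 1.2-fold higher number from compound 1 to compound 2 (0.06 log units; within the scatter)) stayed within the scatter, no shift beyond the scatter is expected in this assay here. The estimated step is small (a 1.1-fold lower number from compound 2 to compound 3 (0.03 log units; within the scatter)) and has no clear direction. For compound 3 the estimated value is 37000 nM (expected range 20000 nM to 68000 nM).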

Compound 3, concentration for 50% growth inhibition: > 50000 nM
Compound 3: a limit, no number (the forecaster's own chance of this, stated with the estimate: 8%); middle value at least 1.3-fold (0.13 log units) from the limit.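

In this assay compound 3 gives > 50000 nM, a limit of the assay and not a number, and the first such result among these compounds: the limit of > 50000 nM in this assay, at which 1 of the 3 values shown sits.

The change that turns 2-hydroxyethyl into 3-hydroxypropyl gives an at least 1.2-fold higher number from compound 2 to compound 3 (0.10 log units; that floor lies within the scatter), and putting hydroxymethyl in place of hydrogen on the saturated chain carbon gives an at least 1.4-fold higher number from compound 1 to compound 3 (0.16 log units; that floor lies within the scatter). Both steps are only floors, and both floors lie within the scatter, so this longer chain may have raised the number at this position, but the data do not show that it did, and compound 3 cannot yet be ranked against either shorter-chain compound.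

The compounds shown leave open how far the number for compound 3 really lies from those of compound 1 and compound 2, and so whether any change at this position moves growth inhibition beyond the scatter. How an amine or a carboxylic acid in place of the hydroxy, or a still longer chain, would read in this assay also remains an open question.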